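Oxime substituent swap on a thioether aryl core

The source may hold more compounds than are shown below. What is called first, only, known or untested is meant among the compounds shown, and "the series" means these compounds.

Compound 1 `CO[C@]1(c2cc(F)cc(S(=O)(=O)c3ccc(/C(C)=N/O)cc3)c2)CCO[C@@H](C)C1`: in a functional assay (blood) for inhibition, with Homo sapiens as the target (a higher number here means a weaker inhibitor, a lower number a stronger inhibitor), compound 1 gives 20 nM
Compound 2 `C/C(=N\OCCSc1nnnn1C)c1ccc(Sc2cc(F)cc(C3CCOCC3)c2)cc1`: in this assay compound 2 gives 120 nM
Compound 3 `CCOC(=O)/C(=N\O)c1ccc(Sc2cc(F)cc(C3CCOCC3)c2)cc1`: in this assay compound 3 gives 170 nM

Among the three measured compounds, compound 3 carries the highest number in this assay. Its nearest neighbour is compound 2, whose number lies within the usual scatter of the measurement, so the two cannot be ordered. Compound 1 lies furthest away, and that gap is beyond the scatter.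

Compound 4 `CC(C)/C(=N\O)c1ccc(Sc2cc(F)cc(C3CCOCC3)c2)cc1` has not yet been measured. It differs from compound 3 in one place: isopropyl in place of ethoxycarbonyl on a carbon with a double bond to nitrogen. Within the data shown here, no measured pair isolates this change, so the size of its effect is open. The three measured compounds with varied groups on the oxime carbon span a moderate range, and nothing here points to a large shift in either direction for this swap. A step within or near the scatter, tilting slightly toward a lower number, is the expectation for compound 4 in this assay, that is a 1.4-fold lower number from compound 3 to compound 4 (0.15 log units; within the scatter). Compound 4 is therefore estimated at 120 nM, with a likely range from 40 nM to 400 nM.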

Compound 4, half-maximal inhibitory concentration: 300 nM
Compound 4: the middle estimate sits 2.5-fold (0.40 log units) below what was measured, within the range that was stated.
By their numbers in this assay, from the lowest: compound 1; then compounds 2, 3 and 4 (each within the scatter of the next, the first and the last beyond it).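

In this assay, isopropyl in place of ethoxycarbonyl on a carbon with a double bond to nitrogen gives a 1.8-fold higher number from compound 3 to compound 4 (0.25 log units; within the scatter) and this step lies within the scatter. Among these compounds, this is the first pair that isolates a change at this position, and on this shared core the two groups cannot be ordered, even though ethoxycarbonyl has more heavy atoms and two hydrogen-bond acceptors where isopropyl has none. No measured evidence bears on this result, and nothing shown says what lies behind it.

Going by these compounds, whether an amine or a carboxylic acid on this carbon would move the number beyond the scatter remains open. On these data alone, it is also open whether the same swap would read alike on the core of compound 1, which differs from compound 3 in more than one place.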